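Swapping the piperazine substituent toward a pyridinylmethyl group

A few compounds are considered here, and "the series" means these few. Any claim that something is new, unique, unknown or untested is made for them only; others in the source may bear on it.

Of the compounds shown here, three sharing one core have been measured in a functional assay on MGC-803 cells (Homo sapiens) for antiproliferative activity, read by CCK-8 assay, with a stated time of 72 h, tested at 8 uM; on this read-out lower numbers stand for a weaker effect and higher numbers for a stronger effect at the one concentration tested. Compound 1 `Nc1ccccc1NC(=O)c1ccc(CSC(=S)N2CCN(C(c3ccccc3)c3ccccc3)CC2)cc1` gives 9.9%, compound 2 `COc1ccc(N2CCN(C(=S)SCc3ccc(C(=O)Nc4ccccc4N)cc3)CC2)cc1` gives 22.9%, and compound 3 `Nc1ccccc1NC(=O)c1ccc(CSC(=S)N2CCCc3ccccc32)cc1` gives 87.5%. On these numbers compound 2 stands second of three: it lies above compound 1 by a margin beyond the scatter, and far below compound 3, again beyond the scatter.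

Compound 4 `Nc1ccccc1NC(=O)c1ccc(CSC(=S)N2CCN(Cc3cccnc3)CC2)cc1` has not yet been measured in this assay. It differs from compound 2 in one place: (pyridin-3-yl)methyl in place of 4-methoxyphenyl on an amine nitrogen in a ring. Compound 1 and compound 2, which both carry a large group on that same amine nitrogen in a ring, sit at the weak end, so the change is not expected to move compound 4 far from compound 2 in this assay. The step of a number 2.9 percentage points lower from compound 2 to compound 4 (within the scatter) is estimated to stay within the scatter, with no clear direction. Compound 4 is therefore expected to give about 20% in this assay, somewhere between 5% and 45%.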

Compound 4, a percentage reported as inhibition, at one concentration (the size of the read-out at that concentration, not a potency): 64.6%
Compound 4: middle estimate off by 44.6 percentage points, on the low side; measured number above the stated range.
By their numbers in this assay, from the lowest: compound 1; then compound 2; then compound 4; then compound 3.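

In this assay, the step of a number 41.7 percentage points higher from compound 2 to compound 4 (beyond the scatter) shows that this amine nitrogen in the six-membered ring is highly sensitive to what it carries. The two groups are close in heavy-atom count, and each has one six-membered aromatic ring and one hydrogen-bond acceptor, so a large group at this position does not by itself mean a weak effect. Nothing here explains why the step is so large.

The change also alters several features at once, since the methoxy oxygen leaves while a ring nitrogen and a methylene link enter, so the compounds shown leave open which of these matters. A benzyl group, which has the methylene link without the ring nitrogen, or a directly attached pyridin-3-yl group, which has the ring nitrogen without the link, would help separate them.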